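The compounds below may be only part of what the source reports. "The series", "measured", "known", "first", "only" and "open" are said of these compounds alone.

Of the compounds shown here, three of the shared core have been measured. In an assay on HEK293 cells for inhibition of Voltage-dependent T-type calcium channel subunit alpha-1G (Homo sapiens), read by fluorescence, tested at 10 uM (on this read-out higher numbers stand for more inhibition at the one concentration tested (going by the name of the read-out) and lower numbers for less inhibition), compound 1 `CCCc1nc(-c2ccccc2)c(CNCCCN2CCN(c3cccc(OC)c3)CC2)o1` gives 36.4%, the lowest of the three numbers. Compound 2 `CCCc1nc(-c2ccccc2)c(CNCCN2CCN(C(c3ccccc3)c3ccccc3)CC2)o1` gives 71.9% in this assay, and compound 3 `CCCc1nc(-c2ccccc2)c(CNCCN2CCN(c3ccccc3Cl)CC2)o1` gives 60.1%; both numbers lie beyond the scatter above that of compound 1, with compound 3 the nearer and compound 2 the further of the two.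

Compound 4 `CCCc1nc(-c2ccccc2)c(CNCCCN2CCN(c3cccc(C)c3)CC2)o1` has not yet been measured. It differs from compound 1 in one place: methyl in place of methoxy on an aromatic carbon. For the measured compounds named here, no measured pair shows this change, so its effect in this assay has no precedent here. A small step is expected, a number 1.6 percentage points higher from compound 1 to compound 4 (within the scatter), lying within the scatter in either direction. For compound 4 the estimate in this assay is 38%, with a range from 22% to 55%.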

Compound 4, a percentage reported as inhibition, at one concentration (the size of the read-out at that concentration, not a potency): 47.8%
Compound 4: middle estimate off by 9.8 percentage points, on the low side, and the stated range covers the measured number.
By their numbers in this assay, from the lowest: compound 1; then compound 4; then compound 3; then compound 2.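

Replacing 3-methoxyphenyl with 3-methylphenyl gives the series its first one-place comparison, and this assay shows a number 11.4 percentage points higher from compound 1 to compound 4 (beyond the scatter) as a result. This place on the aromatic ring therefore registers a change of one small group, with the leaving methoxy carrying one more heavy atom and one hydrogen-bond acceptor than the entering methyl. No measurement available here bears on what lies behind this step.

From the compounds shown here alone, how a hydroxy, amine or trifluoromethyl group would read at this place remains open. So does whether the methoxy-to-methyl change would give a similar step on the chain of compound 3.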